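This account rests on a few compounds, and the source may have more. Where it says the series, first, only, none or still open, it means among the compounds named here.

Measured compounds and their values:
compound 1 `Cn1ccc(NC(=O)c2cn(Cc3ccc(-n4cccn4)cc3)c3cccnc23)n1` — 31 mL/min/kg
compound 2 `Cc1cnc2c(C(=O)N[C@H]3CCOC[C@@H]3O)cn(Cc3ccc(-c4ccn(C)n4)cc3)c2c1` — 2.5 mL/min/kg
compound 3 `O=C(N[C@H]1CCCC[C@@H]1O)c1cn(Cc2ccc3ncccc3c2)c2cccnc12` — 87 mL/min/kg

In an ADME assay on liver for metabolic stability, with Liver microsome (Homo sapiens) as the target, using microsomes (on this read-out lower numbers stand for slow clearance and higher numbers for fast clearance), compound 1 stands second highest of the three numbers. Its nearest neighbour is compound 3, whose number is higher by a margin beyond the usual scatter, and its furthest is compound 2, whose number lies far lower.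

Compound 4 `O=C(N[C@H]1CCCC[C@@H]1O)c1cn(Cc2ccc(-n3cccn3)cc2)c2cccnc12` has not yet been measured. It differs from compound 1 in one place: 2-hydroxycyclohexyl in place of 1-methyl-1H-pyrazol-3-yl on an amide-type nitrogen. For the measured compounds named here, no step between measured compounds matches this change, so its size can only be expected, not read off. A modest rise seems likely, because compound 3 also carries a 2-hydroxycyclohexyl group on its amide nitrogen and shows 87 mL/min/kg. Compound 4 is therefore expected at 45 mL/min/kg, within a range of 18 mL/min/kg to 110 mL/min/kg, a step of a 1.5-fold higher number from compound 1 to compound 4 (0.16 log units; within the scatter).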

Compound 4, clearance: 59 mL/min/kg
The estimate for compound 4 lay 1.3-fold (0.12 log units) below the measured number, within the range that was stated.
By their numbers in this assay, from the lowest: compound 2; then compounds 1, 4 and 3 (each within the scatter of the next, the first and the last beyond it).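

In this assay, putting 2-hydroxycyclohexyl in place of 1-methyl-1H-pyrazol-3-yl on the amide-type nitrogen gives a 1.9-fold higher number from compound 1 to compound 4 (0.28 log units; within the scatter). On this read-out the two groups therefore cannot be told apart at this position, even though one is a five-membered aromatic ring and the other a non-aromatic carbon ring with a hydrogen-bond donor and two defined stereocentres. Nothing available explains this result.

On these data alone, whether an amine, a carboxylic acid or a longer alkyl chain on this nitrogen would read differently stays open. So does whether the same exchange would give a similar step on the core of compound 2.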